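Bromoacetamide Chalcone: Bromobenzyl Swapped for Decyl

The compounds below may be only part of what the source reports. "The series", "measured", "known", "first", "only" and "open" are said of these compounds alone.

Of the compounds shown here, three with a shared core have been measured. Compound 2 `O=C(CBr)Nc1ccc(C(=O)/C=C/c2cn(Cc3ccc(Br)cc3)nn2)cc1` gives 7950 nM in a functional assay on HeLa cells (Homo sapiens) for inhibition, read by MTT assay (on this read-out lower numbers stand for stronger inhibition and higher numbers for weaker inhibition), the lowest of the three numbers, so it is the most potent among them. Compound 3 `COc1ccccc1N1CCN(CC(=O)Nc2ccc(C(=O)/C=C/c3cn(Cc4ccc(Br)cc4)nn3)cc2)CC1` gives 26400 nM in this assay, and compound 1 `CCCCCCCCCCn1cc(/C=C/C(=O)c2ccc(NC(=O)CN3CCC(Cc4ccccc4)CC3)cc2)nn1` gives 71700 nM; both gaps from compound 2 lie beyond the usual scatter. Compound 4 `CCCCCCCCCCn1cc(/C=C/C(=O)c2ccc(NC(=O)CBr)cc2)nn1` is not yet measured. It differs from compound 2 in one place: nonyl in place of 4-bromophenyl on a saturated chain carbon bound to an aromatic nitrogen. Within the data shown here, no measured pair differs only in this way, since compound 1 and compound 3 carry other changes alongside. The step from compound 2 to compound 4 is expected to be a moderate weakening, a 2.0-fold higher number from compound 2 to compound 4 (0.30 log units; within the scatter), though it could stay within scatter. Compound 4 is estimated at 16000 nM, with a range from 5000 nM to 50000 nM.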

Compound 4, half-maximal inhibitory concentration: 7410 nM
Compound 4: the middle estimate sits 2.2-fold (0.33 log units) above what was measured; the range from low to high includes it.
By their numbers in this assay, from the lowest: compounds 4 and 2 (each within the scatter of the next); then compound 3; then compound 1.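

The step of a 1.1-fold lower number from compound 2 to compound 4 (0.03 log units; within the scatter) in this assay shows that, with the bromoacetamide end kept, this position takes a long open chain as readily as a bromine-bearing ring. Compound 1 and compound 3 could not show this, since they carry other changes alongside. No evidence here explains why the swap leaves the number within the scatter. Going by these compounds, whether a much shorter chain such as butyl, or a chain ending in an amine, would fare the same remains open. So does whether this swap holds with other amide end groups.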